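Trifluoromethyl in place of dimethylamino: working notes

This account rests on a few compounds, and the source may have more. Where it says the series, first, only, none or still open, it means among the compounds named here.

Measured in a functional assay on T47D cells (Homo sapiens) for cytotoxicity, read by MTT assay, with a stated time of 2 days; a lower number here means a stronger inhibitor, a higher number a weaker inhibitor:
- compound 1 `Cc1ccc2nc(-c3ccccc3N(C)C)[nH]c(=O)c2c1`: 26700 nM
- compound 2 `CN(C)c1ccc2nc(-c3cccc4ccccc34)[nH]c(=O)c2c1`: > 50000 nM

Within the data shown here, compound 1 holds the only actual number, 26700 nM. Compound 2 gives > 50000 nM, which is a limit of the assay and not a number.

Compound 3 `Cc1ccc2nc(-c3ccccc3C(F)(F)F)[nH]c(=O)c2c1` keeps the core of compound 1 and carries trifluoromethyl in place of dimethylamino on an aromatic carbon, ortho to a large group (trifluoromethyl in place of dimethylamino on an aromatic carbon). Among the measured compounds shown here, no measured step bears on this change, so the expectation starts from compound 1 at 26700 nM, and no step beyond the scatter is expected in this assay, in either direction. The expected step is a 1.1-fold higher number from compound 1 to compound 3 (0.05 log units; within the scatter). For compound 3 the estimated value is 30000 nM. The expected range for compound 3 runs from 12000 nM to 50000 nM.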

Compound 3, half-maximal inhibitory concentration: > 50000 nM
Compound 3: no number, only a limit; the forecaster's own chance of this, stated with the estimate: 30%; middle value at least 1.6-fold (0.22 log units) from the limit.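

On an aromatic carbon, ortho to a large group, trifluoromethyl in place of dimethylamino gives an at least 1.8-fold higher number from compound 1 to compound 3 (0.27 log units; that floor lies within the scatter) in this assay. Among these compounds, this is the only step that can be read, and it has a floor only, so it does not establish a change beyond the scatter, and its full size stays unknown. That floor is set by the assay's limit: the limit of > 50000 nM in this assay, at which 2 of the 3 values shown sit.

The compounds shown leave open whether another group at this place, such as methoxy, a primary amine or a carboxylic acid, would give an actual number in this assay. They also leave open whether the dimethylamino group of compound 1 matters at all, as only one replacement at this place is shown and it ends in a limit.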